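Cell Toxicity of Three Measured Amines and One Untested Analogue

The source may report more compounds than this note shows. Statements on the series, on what has been measured and on what is new or still open speak of the compounds shown alone.

Three compounds have been measured in an ADME assay on Huh-7 cells (Homo sapiens) for cytotoxicity; on this read-out higher numbers stand for lower toxicity in this test and lower numbers for higher toxicity in this test:

- compound 1 `CN1CCN(CCCNCc2cn(-c3ccc(C(F)(F)F)cc3)nc2-c2ccc(C(F)(F)F)cc2)CC1` gives 2000 nM
- compound 3 `CCCN1CCC(CNCc2cn(-c3ccc(C(F)(F)F)cc3)nc2-c2ccc(C(F)(F)F)cc2)CC1` gives 1200 nM
- compound 2 `CCCN1CCC(CNCc2cn(-c3ccc(F)cc3F)nc2-c2ccccc2C)CC1` gives > 20000 nM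

The value for compound 2 is a limit of the assay and not a number (the limit of > 20000 nM in this assay, at which 1 of the 3 values shown sits). Compound 3 and compound 1 differ in one place, (2-(4-methylpiperazin-1-yl)ethyl in place of 1-propylpiperidin-4-yl on a saturated chain carbon bound to an amine nitrogen), and that change made a 1.7-fold higher number from compound 3 to compound 1 (0.22 log units; within the scatter).

Compound 4 `Cc1ccccc1-c1nn(-c2ccc(F)cc2F)cc1CNCCCN1CCN(C)CC1` has not yet been measured in this assay. It differs from compound 2 by the same change, (2-(4-methylpiperazin-1-yl)ethyl in place of 1-propylpiperidin-4-yl on a saturated chain carbon bound to an amine nitrogen), at the same place as before. The difference between the core of compound 2 and the core of compound 3 is not broken down here.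

Compound 4 is expected to move from compound 2 by about a step that the limit leaves unreadable from compound 2 to compound 4 in this assay, an expectation that rests on a 1.7-fold higher number from compound 3 to compound 1 (0.22 log units; within the scatter) being within the scatter and on compound 2 sitting at the limit > 20000 nM. The estimate for compound 4 is therefore 30000 nM, between 15000 nM and 80000 nM, most likely reported again only as a limit.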

Compound 4, half-maximal cytotoxic concentration: > 20000 nM
Compound 4: no number, only a limit (the forecaster's own chance of this, stated with the estimate: 75%); the middle value is on the limit's open side.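

Compound 2 and compound 4 both stop at a limit of the assay and not at a number, so the step between them cannot be read: the limit of > 20000 nM in this assay, at which 2 of the 4 values shown sit.

The compounds shown leave open whether 2-(4-methylpiperazin-1-yl)ethyl in place of 1-propylpiperidin-4-yl changes the cytotoxicity read-out at all on the core of compound 2.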